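This account rests on a few compounds, and the source may have more. Where it says the series, first, only, none or still open, it means among the compounds named here.

Measured compounds:
compound 1, `CCOC(=O)/C(O)=C/C(=O)c1cn(Cc2ccc(F)c(F)c2)c2cccc(OC)c12`: 125000 nM
compound 2, `COc1cccc2c1c(C(=O)/C=C(\O)C(=O)O)cn2Cc1cc(F)ccc1F`: 46200 nM
compound 3, `CCOC(=O)/C(O)=C/C(=O)c1cn(Cc2c(F)ccc(F)c2F)c2cccc(OC)c12`: 40500 nM

In an ADME assay on MT4 cells (Homo sapiens) for cytotoxicity, read by MTT assay (a higher number here means that more compound is tolerated, a lower number that less compound is tolerated), compound 3 gives the lowest of the three numbers, though compound 2 sits within the scatter of it; only compound 1 stands clearly apart. Going by the values given here, the one measured step between neighbouring structures, a 3.1-fold lower number from compound 1 to compound 3 (0.49 log units; beyond the scatter), came from rearranging the fluorine pattern on the benzyl group and was modest.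

Compound 4, `CCOC(=O)/C(O)=C/C(=O)c1cn(Cc2cc(F)ccc2F)c2cccc(OC)c12`, differs from compound 3 by hydrogen in place of fluoro on an aromatic carbon. That is a smaller alteration of the same benzyl group than the step already seen, and compound 2 gives 46200 nM, close to compound 3. So for compound 4 a step of a 1.2-fold higher number from compound 3 to compound 4 (0.09 log units; within the scatter) is expected, not beyond the scatter. Compound 4 is expected to give 50000 nM, between 22000 nM and 115000 nM.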

Compound 4, half-maximal cytotoxic concentration: 41200 nM
Beside the measured number, compound 4's estimate is 1.2-fold (0.08 log units) above it, and the stated range covers the measured number.
By their numbers in this assay, from the lowest: compounds 3, 4 and 2 (each within the scatter of the next); then compound 1.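

In this assay, hydrogen in place of fluoro on this aromatic carbon gives a 1.0-fold higher number from compound 3 to compound 4 (0.01 log units; within the scatter), so the two compounds cannot be told apart and this fluoro group makes no readable difference here. With a 3.0-fold lower number from compound 1 to compound 4 (0.48 log units; beyond the scatter), the 2,5-difluorophenyl compound stands as clearly apart from compound 1 as the trifluorinated compound 3 does. With the same benzyl group, ethyl in place of hydrogen on the oxygen gives a 1.1-fold lower number from compound 2 to compound 4 (0.05 log units; within the scatter), again no readable difference.

Going by these compounds, whether a chloro or methyl group at this place would also read alike stays open. Nothing here gives a measured reason for these numbers.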